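The compounds below may be only part of what the source reports. "The series", "measured", "known", "first", "only" and "open" are said of these compounds alone.

Measured so far in an assay on isolated protein for inhibition of histone deacetylase 4 (Homo sapiens), with a stated time of 1 h; a lower number here means a stronger inhibitor, a higher number a weaker inhibitor:

Compound 1, `Cc1ccc(NC(=O)COc2ccc3cc(/C=C4/SC(=O)NC4=O)ccc3c2)cc1`: 1700 nM
Compound 2, `O=C(COc1ccc2cc(/C=C3/SC(=O)NC3=O)ccc2c1)Nc1ccc(Br)cc1F`: 1900 nM
Compound 3, `Cc1cccc2sc(NC(=O)COc3ccc4cc(/C=C5/SC(=O)NC5=O)ccc4c3)nc12`: 1200 nM

On these three numbers compound 3 sits at the low end, but a 1.4-fold lower number from compound 1 to compound 3 (0.15 log units; within the scatter) and a 1.6-fold lower number from compound 2 to compound 3 (0.20 log units; within the scatter) are both within the scatter, so the three compounds are not separated from one another in this assay. The same holds for a 1.1-fold higher number from compound 1 to compound 2 (0.05 log units; within the scatter).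

Compound 4, `O=C(COc1ccc2cc(/C=C3/SC(=O)NC3=O)ccc2c1)Nc1cccc(Cl)c1`, has not yet been measured. It differs from compound 3 in one place: 3-chlorophenyl in place of 4-methyl-1,3-benzothiazol-2-yl on an amide-type nitrogen. The three steps already measured all vary the group on this same amide-type nitrogen, exchanging 4-methylphenyl, 4-bromo-2-fluorophenyl and 4-methyl-1,3-benzothiazol-2-yl, and none of them moved the number beyond the scatter. The move to 3-chlorophenyl is a further exchange at that position, so no step beyond the scatter is expected in this assay, in either direction.

Compound 4 is therefore expected to give about 1600 nM, with a plausible range from 800 nM to 3200 nM. The expected step of a 1.3-fold higher number from compound 3 to compound 4 (0.12 log units; within the scatter) is estimated to stay within the scatter.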

Compound 4, half-maximal inhibitory concentration: 3800 nM
For compound 4 the middle estimate is 2.4-fold (0.38 log units) below the measured one; measured number outside the range, above it.
By their numbers in this assay, from the lowest: compounds 3, 1, 2 and 4 (each within the scatter of the next, the first and the last beyond it).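

In this assay, the group on the amide-type nitrogen had produced no step beyond the scatter among the first three compounds, but it now does: 3-chlorophenyl in place of 4-methyl-1,3-benzothiazol-2-yl gives a 3.2-fold higher number from compound 3 to compound 4 (0.50 log units; beyond the scatter), and 3-chlorophenyl in place of 4-methylphenyl gives a 2.2-fold higher number from compound 1 to compound 4 (0.35 log units; beyond the scatter), both modest in size. Set against 4-bromo-2-fluorophenyl, the same group gives a 2.0-fold higher number from compound 2 to compound 4 (0.30 log units; within the scatter), so compound 4 is separated from compound 3 and compound 1 but not from compound 2, and the position is shown to respond to the exchange of one aromatic group for another only to a modest extent. Nothing available here bears on what lies behind these steps.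

Every group shown on this nitrogen contains an aromatic ring, so the effect of a longer chain or a simple alkyl group in its place remains open. Also open, from the compounds shown here alone, are whether the chlorine of compound 4 matters, as against an unsubstituted phenyl, and what an amine or a carboxylic acid on that ring would do in this assay.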